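This account rests on a few compounds, and the source may have more. Where it says the series, first, only, none or still open, it means among the compounds named here.

Measured in an ADME assay on the whole organism (Mus musculus, strain C57BL6/N) for pharmacokinetics, read by LC-MS, with a stated time of 24 h, at a dose of 50 mg/kg by the oral route; on this read-out lower numbers stand for lower exposure and higher numbers for higher exposure at the dose given:
- compound 1 `CNc1cc(C)c(C(N)=O)cn1` gives 235000 nM
- compound 2 `C[C@@H]1Cc2cc(C(N)=O)cnc2N1` gives 127000 nM
- compound 3 `NC(=O)c1cnc2c(c1)CCN2` gives 176000 nM

In this assay compound 3 gives 176000 nM, within the scatter of both other compounds, so these three cannot be ranked. Compound 4 `Cc1c(C(N)=O)cnc2c1CCN2` has methyl in place of hydrogen on an aromatic carbon, ortho to a carbamoyl group: methyl in place of hydrogen on an aromatic carbon. Going by the values given here, the only measured step with a methyl is a 1.4-fold higher number from compound 2 to compound 3 (0.14 log units; within the scatter), with hydrogen in place of methyl on a saturated ring carbon, so it involves a different kind of carbon. Compound 1 also has a methyl ortho to a carbamoyl group, on a different core, and gives 235000 nM. Nothing here points to a real shift. The expected change is a 1.1-fold higher number from compound 3 to compound 4 (0.03 log units; within the scatter), which would not go beyond the scatter. For compound 4 the estimated value is 190000 nM, with an expected range of 100000 nM to 350000 nM.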

Compound 4, maximal plasma concentration: 76400 nM
The estimate for compound 4 lay 2.5-fold (0.40 log units) above the measured number; the measured number lies below the stated range.
By their numbers in this assay, from the lowest: compounds 4, 2, 3 and 1 (each within the scatter of the next, the first and the last beyond it).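

With methyl in place of hydrogen on an aromatic carbon, ortho to a carbamoyl group, this assay shows a 2.3-fold lower number from compound 3 to compound 4 (0.36 log units; beyond the scatter) as the first step among these compounds to clear the scatter. This aromatic carbon therefore responds to a single added methyl, whereas a 1.4-fold higher number from compound 2 to compound 3 (0.14 log units; within the scatter) is the earlier step, at a saturated ring carbon, and stays within the scatter. No available evidence explains the lower exposure.

One methyl at one position cannot show how an ethyl group or an amine on this same carbon would read. It also leaves open whether a methyl here lowers exposure on any other core.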